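A few compounds are considered here, and "the series" means these few. Any claim that something is new, unique, unknown or untested is made for them only; others in the source may bear on it.

- compound 1 `COc1nc(N)nc2c1c(-c1ccco1)cn2[C@@H]1O[C@H](CO)[C@@H](O)[C@H]1O` | > 20000 nM (limit)
- compound 2 `COc1nc(N)nc2c1c(-c1cccs1)cn2[C@@H]1O[C@H](CO)[C@@H](O)[C@H]1O` | > 20000 nM (limit)
- compound 3 `COc1nc(N)nc2c1c(-c1ccccc1)cn2[C@@H]1O[C@H](CO)[C@@H](O)[C@H]1O` | > 20000 nM (limit)

In a functional assay on CCRF-CEM cells (Homo sapiens), read by MTT assay, with a stated time of 72 h (a higher number here means a weaker inhibitor, a lower number a stronger inhibitor), compound 3 stands at > 20000 nM, which is a limit and not a number. Compound 1 and compound 2 also give limits, so compound 3 has no readable place among the three.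

The next change leads to compound 4 `COc1nc(N)nc2c1c(-c1cc3ccccc3o1)cn2[C@@H]1O[C@H](CO)[C@@H](O)[C@H]1O`, with 1-benzofuran-2-yl in place of phenyl on an aromatic carbon. All three measured steps bear on it, as each exchanges one aromatic group for another on that carbon: a step that the two limits leave unreadable from compound 1 to compound 2, a step that the two limits leave unreadable from compound 1 to compound 3 and a step that the two limits leave unreadable from compound 2 to compound 3. None of them has a readable size. Among the compounds with values here, the only evidence is the limit of > 20000 nM in this assay, at which 3 of the 3 values shown sit, and 1-benzofuran-2-yl has no measured counterpart. On that basis, no step beyond the scatter is expected in this assay in either direction. The expected step is a step that the limit leaves unreadable from compound 3 to compound 4, an estimate that rests on limits alone. Compound 4 is estimated at 25000 nM, with an expected range of 10000 nM to 50000 nM, and another limit is the likeliest report.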

Compound 4, half-maximal inhibitory concentration: 12700 nM
Beside the measured number, compound 4's estimate is 2.0-fold (0.29 log units) above it, within the range that was stated.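

In this assay, within the data shown here, compound 4 gives 12700 nM, the first number at this position on the shared core, while the steps among compound 1, compound 2 and compound 3 cannot be read. With 1-benzofuran-2-yl on this aromatic carbon, the series shows an at least 1.5-fold lower number from compound 3 to compound 4 (0.19 log units; that floor lies within the scatter) and an at least 1.5-fold lower number from compound 2 to compound 4 (0.19 log units; that floor lies within the scatter) and an at least 1.5-fold lower number from compound 1 to compound 4 (0.19 log units; that floor lies within the scatter) but these floors alone do not establish a change beyond the scatter. The position therefore accepts a group with two aromatic rings and still gives a measurable value, although limits remain the commonest reading: the limit of > 20000 nM in this assay, at which 3 of the 4 values shown sit.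

The compounds shown do not tell whether this reading follows the second aromatic ring or the ring oxygen of 1-benzofuran-2-yl. A 1-benzothiophen-2-yl or naphthalen-2-yl group on the same carbon would bear on that question, and an aminomethyl group or a carboxylic acid would extend the comparison to groups of a different kind.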